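The source may report more compounds than this note shows. Statements on the series, on what has been measured and on what is new or still open speak of the compounds shown alone.

Compound 1 `NC(=S)Nc1cccc(OCCCCCCc2ccccc2)c1` was examined in an ADME assay on Ava5 cells (Homo sapiens) for cytotoxicity (on this read-out lower numbers stand for higher toxicity in this test and higher numbers for lower toxicity in this test), where compound 1 gives 28000 nM. Compound 2 `NC(=S)Nc1cccc(OCCCCCOc2ccccc2)c1` is its close relative in which the benzyl end of the chain is replaced by a phenoxy end. In this assay compound 2 reaches only a limit of the test, > 50000 nM, and no definite number. The comparison gives an at least 1.7-fold higher number from compound 1 to compound 2 (0.25 log units; that floor lies within the scatter), and as compound 2 sits at the limit of > 50000 nM in this assay, at which 1 of the 2 values shown sits, its standing is known only as a range beyond that point. Compound 3 `CC(CCOc1ccccc1)CCOc1cccc(NC(N)=S)c1` brings a further, smaller change: methyl in place of hydrogen on a saturated chain carbon bound to two saturated chain carbons. Among the measured compounds shown here, none of the measured steps involves a methyl of this kind, and the single measured step is itself within the scatter, so for this assay compound 3 is expected to show a step that the limit leaves unreadable from compound 2 to compound 3, meaning no shift beyond the usual scatter. Compound 3 is therefore estimated at 60000 nM, within a range from 30000 nM to 120000 nM, with a substantial chance that the test again reports only a limit.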

Compound 3, half-maximal cytotoxic concentration: > 50000 nM
Compound 3: no number, only a limit (the forecaster's own chance of this, stated with the estimate: 60%); the middle value is on the limit's open side.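

No step can be read from compound 2 to compound 3 in this assay, since both compounds give only a limit of the test: the limit of > 50000 nM in this assay, at which 2 of the 3 values shown sit.

The compounds shown leave open whether methyl in place of hydrogen changes the read-out at all, and where compound 2 and compound 3 truly lie.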